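A few compounds are considered here, and "the series" means these few. Any claim that something is new, unique, unknown or untested is made for them only; others in the source may bear on it.

Compound 1 `Cc1nnc(SCc2cc(=O)c3ccccc3o2)s1` and compound 2 `Cc1nnc(SCc2cc(=O)c3ccccc3o2)o1` share a core in which a thioether links a saturated chain carbon to a five-membered aromatic ring. In a functional assay on HEp-2 cells (Homo sapiens) for cytotoxicity, read by MTT assay, with a stated time of 72 h (on this read-out higher numbers stand for weaker inhibition and lower numbers for stronger inhibition), compound 1 gives > 25000 nM, which is a limit of the assay rather than a number. In this assay compound 2 likewise gives > 25000 nM, again a limit. Within the data shown here, the one measured step, a step that the two limits leave unreadable from compound 1 to compound 2, is therefore unreadable, and the limit of > 25000 nM in this assay, at which 2 of the 2 values shown sit, is all the evidence there is. Compound 3 `Nc1nnc(SCc2cc(=O)c3ccccc3o2)s1` differs from compound 2 by 5-amino-1,3,4-thiadiazol-2-yl in place of 5-methyl-1,3,4-oxadiazol-2-yl on a sulfur. Among the measured compounds shown here, since compound 2 sits at a limit and the only neighbouring step cannot be sized, no direction can be expected for this change in this assay. For compound 3 the estimate is 30000 nM, in the range 8000 nM to 120000 nM, which means an expected step that the limit leaves unreadable from compound 2 to compound 3.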

Compound 3, half-maximal inhibitory concentration: > 25000 nM
Compound 3 gave a limit, no number (the forecaster's own chance of this, stated with the estimate: 80%); the middle value lies beyond the limit too.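

No new step can be read among compound 1, compound 2 and compound 3, as each gives only a limit in this assay: the limit of > 25000 nM in this assay, at which 3 of the 3 values shown sit.

The compounds shown leave open whether the 5-methyl-1,3,4-thiadiazol-2-yl, 5-methyl-1,3,4-oxadiazol-2-yl and 5-amino-1,3,4-thiadiazol-2-yl groups on a sulfur differ at all in this assay.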